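The source may report more compounds than this note shows. Statements on the series, on what has been measured and on what is new or still open speak of the compounds shown alone.

Measured in a functional assay on HL-60 cells (Homo sapiens) for antiproliferative activity, read by MTT assay, with a stated time of 72 h; a higher number here means a weaker inhibitor, a lower number a stronger inhibitor:
- compound 1 `COc1cc(C(=O)c2sc3ccccc3c2-c2ccc(F)cc2)cc(OC)c1OC`: 3200 nM
- compound 2 `COc1cc(C(=O)c2sc3ccccc3c2-c2ccc(Cl)cc2)cc(OC)c1OC`: 3300 nM
- compound 3 `COc1cc(C(=O)c2sc3ccccc3c2-c2ccc(SC)cc2)cc(OC)c1OC`: 1300 nM

Compound 3, at 1300 nM, has the lowest number of the three. The next compound, compound 4 `COc1ccc(-c2c(C(=O)c3cc(OC)c(OC)c(OC)c3)sc3ccccc23)c(OC)c1`, carries 2,4-dimethoxyphenyl in place of 4-(methylsulfanyl)phenyl on an aromatic carbon.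

The closest evidence comes from the measured swaps on this same aromatic ring: a 1.0-fold higher number from compound 1 to compound 2 (0.01 log units; within the scatter), a 2.5-fold lower number from compound 1 to compound 3 (0.39 log units; beyond the scatter) and a 2.5-fold lower number from compound 2 to compound 3 (0.40 log units; beyond the scatter). All of these are modest or smaller, but none tests a dimethoxy pattern, so the forecast is uncertain. Since compound 3 already sits lowest at 1300 nM, a modest move to a higher number is expected: a 1.9-fold higher number from compound 3 to compound 4 (0.28 log units; within the scatter). For compound 4 the estimated value is 2500 nM, with an expected range of 800 nM to 8000 nM.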

Compound 4, half-maximal inhibitory concentration: 4600 nM
Compound 4: middle estimate off by 1.8-fold (0.26 log units), on the low side; measured number inside the range.
By their numbers in this assay, from the lowest: compound 3; then compounds 1, 2 and 4 (each within the scatter of the next).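

Putting 2,4-dimethoxyphenyl in place of 4-(methylsulfanyl)phenyl on this aromatic carbon gives a 3.5-fold higher number from compound 3 to compound 4 (0.55 log units; beyond the scatter) and so loses the advantage held by compound 3. The same group in place of 4-chlorophenyl gives a 1.4-fold higher number from compound 2 to compound 4 (0.14 log units; within the scatter) and in place of 4-fluorophenyl gives a 1.4-fold higher number from compound 1 to compound 4 (0.16 log units; within the scatter) and so does not separate from those halogen-bearing compounds. No measurement available here explains this result.

On these data alone, compound 4 differs from compound 3 by two methoxy groups at once, so the part played by each remains open. As far as these compounds go, how a single methoxy group or an amine on this ring would behave also remains unknown.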